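Trimming the basic side chain: an estimate for compound 3

The compounds below may be only part of what the source reports. "The series", "measured", "known", "first", "only" and "open" are said of these compounds alone.

compound 1: `CC(C1=C(CCN2CCCC2)Cc2ccccc21)c1ccccn1` — 2000 nM
compound 2: `CC(C1=C(CCCN(C)C)Cc2ccccc21)c1ccccn1` — 3240 nM

Of the compounds shown here, two have been measured in an assay on CHO-K1 cells for binding affinity to muscarinic acetylcholine receptor M5 (Homo sapiens); on this read-out lower numbers stand for stronger inhibition and higher numbers for weaker inhibition. Compound 1 gives 2000 nM and compound 2 gives 3240 nM; the step of a 1.6-fold higher number from compound 1 to compound 2 (0.21 log units; within the scatter) lies within the scatter, so the two values cannot be told apart. Compound 3 `CC(C1=C(CN(C)C)Cc2ccccc21)c1ccccn1` differs from compound 2 in one place: dimethylamino in place of 2-(dimethylamino)ethyl on a saturated chain carbon bound to a double-bonded ring carbon. Among the measured compounds shown here, the only measured step swapped one amine for another while keeping the chain length; it does not speak to shortening the chain itself. For the measured compounds named here, no measured step therefore bears directly on this change, and the expectation rests on the step size being unknown. Compound 3 is expected to show a somewhat weaker number, with wide uncertainty, the step of a 1.9-fold higher number from compound 2 to compound 3 (0.27 log units; within the scatter) being only a guess. Compound 3 is thus estimated at 6000 nM, in a range from 2000 nM to 20000 nM.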

Compound 3, inhibition constant: 87.1 nM
The estimate for compound 3 lay 69-fold (1.84 log units) above the measured number; the measured number lies below the stated range.
By their numbers in this assay, from the lowest: compound 3; then compounds 1 and 2 (each within the scatter of the next).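

This position turns out to be far from indifferent. The earlier pair gave no readable change in this assay, whereas trimming 3-(dimethylamino)propyl to (dimethylamino)methyl gives a 37-fold lower number from compound 2 to compound 3 (1.57 log units; beyond the scatter). Compound 1 shows a similar result, with a 23-fold lower number from compound 1 to compound 3 (1.36 log units; beyond the scatter), so the shorter side chain of compound 3 stands apart from both longer-chained compounds, and no supporting data are available to explain why.

The compounds shown cannot tell whether this large step depends on the shorter chain alone or also on the dimethylamino group it carries. Putting a pyrrolidine, a piperidine or a morpholine on the same short chain, or testing a primary amine there, would help separate the two and show how much freedom this end of the molecule allows.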